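The source may hold more compounds than are shown below. What is called first, only, known or untested is meant among the compounds shown, and "the series" means these compounds.

Going by the values given here, compound 2 `CC(=O)Oc1ccccc1C(=O)O[C@H]1CO[C@H]2[C@@H]1OC[C@H]2OC(=O)c1cccc(O)c1` gives 0.0183 h in an ADME assay on a cell-free system (plasma, Homo sapiens) for metabolic stability, with Plasma (Rattus norvegicus) as the target, read by HPLC, at pH 7.4 (on this read-out higher numbers stand for a longer-lived compound and lower numbers for a shorter-lived compound), the lowest of the three numbers measured so far. Compound 1 `CC(=O)Oc1ccccc1C(=O)O[C@H]1CO[C@H]2[C@@H]1OC[C@H]2O` gives 0.055 h in this assay, and compound 3 `COc1ccccc1C(=O)O[C@@H]1CO[C@H]2[C@@H]1OC[C@@H]2OC(=O)c1ccccc1OC(C)=O` gives 0.0578 h. The measured steps show a 3.0-fold lower number from compound 1 to compound 2 (0.48 log units; beyond the scatter) and a 3.2-fold higher number from compound 2 to compound 3 (0.50 log units; beyond the scatter), while a 1.1-fold higher number from compound 1 to compound 3 (0.02 log units; within the scatter).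

Compound 4 `COc1cccc(C(=O)O[C@@H]2CO[C@H]3[C@@H]2OC[C@@H]3OC(=O)c2ccccc2OC(C)=O)c1` differs from compound 2 by methyl in place of hydrogen on an oxygen on an aromatic ring. The step from compound 2 to compound 3 bears on this change most directly, as it replaces the 3-hydroxyphenyl group and recovers the level of compound 1; it also shifts the substituent, so only part of it can be carried over. A modest rise is therefore expected, a 2.2-fold higher number from compound 2 to compound 4 (0.34 log units; beyond the scatter), and compound 4 is estimated at 0.04 h, with a range from 0.015 h to 0.09 h.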

Compound 4, half-life: 0.0525 h
For compound 4 the middle estimate is 1.3-fold (0.12 log units) below the measured one; measured number inside the range.
By their numbers in this assay, from the lowest: compound 2; then compounds 4, 1 and 3 (each within the scatter of the next).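

Hydroxy to methoxy, as a single change on the aromatic ring, gives a 2.9-fold higher number from compound 2 to compound 4 (0.46 log units; beyond the scatter) and so isolates what the step to compound 3 showed only together with a move from 3-hydroxyphenyl to 2-methoxyphenyl. Both a 1.1-fold lower number from compound 3 to compound 4 (0.04 log units; within the scatter) and a 1.0-fold lower number from compound 1 to compound 4 (0.02 log units; within the scatter) leave compound 2 alone standing apart among the four compounds shown.

Nothing at hand explains the rise from hydroxy to methoxy. As far as these compounds go, whether an amine or a carboxylic acid in place of the methoxy would stay at this level remains open.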